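A Larger Side Chain on a Highly Soluble Amide

A few compounds are considered here, and "the series" means these few. Any claim that something is new, unique, unknown or untested is made for them only; others in the source may bear on it.

Compound 1, `CC(C)C[C@H](N)C(=O)N[C@@H]1CN(c2nc3c(cc2F)c(=O)c(C(=O)O)cn3C2CC2)[C@H]1C`, and compound 2, `C[C@H](N)C(=O)N[C@@H]1CN(c2cc3c(cc2F)c(=O)c(C(=O)O)cn3-c2ccc(F)cc2F)[C@H]1C`, were both examined in a physicochemical assay for solubility; on this read-out higher numbers stand for higher solubility and lower numbers for lower solubility. In this assay compound 1 gave > 500 ug/mL, which is a limit of the measurement rather than a number. Compound 2 likewise gave > 500 ug/mL, also a limit, and the limit of > 500 ug/mL in this assay, at which 2 of the 2 values shown sit, marks where both values sit. Compound 3, `CCC[C@H](N)C(=O)N[C@@H]1CN(c2cc3c(cc2F)c(=O)c(C(=O)O)cn3-c2ccc(F)cc2F)[C@H]1C`, differs from compound 2 by ethyl in place of hydrogen on a saturated chain carbon, two bonds along the chain from an amine nitrogen and a carbonyl carbon. Among the measured compounds shown here, no measured step between two compounds exists here, so the size of this change cannot be read from neighbours. Compound 3 is expected to stay near the same limit, with the step of a number no higher from compound 2 to compound 3 (the limit leaves the size open) estimated to lie within the scatter. Compound 3 is thus estimated at 500 ug/mL, in the range 200 ug/mL to 1000 ug/mL.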

Compound 3, solubility: > 500 ug/mL
Compound 3 ended at the assay's limit (the forecaster's own chance of this, stated with the estimate: 60%); the middle value sits exactly at the limit.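

Among the compounds shown here, no step from compound 2 to compound 3 can be read in this assay, since both values are limits of the measurement. The compounds shown leave open how large the true values are and whether ethyl in place of hydrogen changes them at all.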